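Ethyl in place of hydrogen on the shared core

The source may hold more compounds than are shown below. What is called first, only, known or untested is meant among the compounds shown, and "the series" means these compounds.

Compound 1 `O=c1c(-c2nn[nH]n2)c[nH]c2ccccc12` is the unsubstituted parent. In a functional assay on the whole organism (strain Sprague-Dawley) for inhibition, with Rattus norvegicus as the target (a higher number here means that more compound is needed for the effect, a lower number that less compound is needed), compound 1 gives only a limit, > 20 mg/kg, so its own position is known just as a bound (the limit of > 20 mg/kg in this assay, at which 1 of the 3 values shown sits). Compound 2 `CSc1cccc2c(=O)c(-c3nn[nH]n3)c[nH]c12` gives 25 mg/kg in this assay, and compound 3 `CC(C)Oc1cccc2c(=O)c(-c3nn[nH]n3)c[nH]c12` gives 1.25 mg/kg. Two steps are readable: from compound 2 to compound 3 the change is a 20-fold lower number from compound 2 to compound 3 (1.30 log units; beyond the scatter), and from compound 1 to compound 3 it is an at least 16-fold lower number from compound 1 to compound 3 (1.20 log units; beyond the scatter), while a step that the limit leaves unreadable from compound 1 to compound 2 cannot be sized. Compound 4 `CCc1ccc2[nH]cc(-c3nn[nH]n3)c(=O)c2c1` differs from compound 1 by ethyl in place of hydrogen on an aromatic carbon. The measured steps add groups carrying an oxygen or sulfur; ethyl carries neither, so they bear on this change only loosely, and the large gain seen in compound 3 is not assumed to carry over. A modest lowering beyond the scatter is expected at most, an at least 2.0-fold lower number from compound 1 to compound 4 (0.30 log units; that floor lies within the scatter). Compound 4 is therefore estimated at 10 mg/kg in this assay, within 3 mg/kg to 40 mg/kg.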

Compound 4, minimum effective dose: 0.625 mg/kg
The estimate for compound 4 lay 16-fold (1.20 log units) above the measured number; measured number below the stated range.
By their numbers in this assay, from the lowest: compounds 4 and 3 (each within the scatter of the next); then compound 2.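

In this assay compound 1 gives > 20 mg/kg, a limit of the assay: the limit of > 20 mg/kg in this assay, at which 1 of the 4 values shown sits.

Ethyl in place of hydrogen gives an at least 32-fold lower number from compound 1 to compound 4 (1.50 log units; beyond the scatter), so a large step on the shared core does not require an oxygen or sulfur in the entering group. Ethyl has no hydrogen-bond donors or acceptors and no ring, and at this aromatic carbon, meta to a fused ring and para to a fused ring, such a small carbon-only group is enough for a step of this size.

As far as these compounds go, how the effect follows chain size at this carbon remains open, as a methyl or a longer chain such as propyl would be needed to tell. Also open, from the compounds shown here alone, is how an amine or a carboxylic acid would behave at the same place, and whether isopropoxy would keep its effect there.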